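The source may hold more compounds than are shown below. What is called first, only, known or untested is meant among the compounds shown, and "the series" means these compounds.

Series notes. The three measured compounds share one core and differ only in the methoxyphenyl group on the benzylic carbon. Compound 1 `COc1ccccc1COc1ccccc1OCCNCCOc1c(OC)cccc1OC` gives 8.53 in a functional assay on Vas deferens for antagonist activity at Alpha-1A adrenergic receptor (Rattus norvegicus); on this read-out lower numbers stand for lower potency and higher numbers for higher potency (the scale is a negative logarithm); compound 2 `COc1cccc(COc2ccccc2OCCNCCOc2c(OC)cccc2OC)c1` gives 8.3; compound 3 `COc1ccc(COc2ccccc2OCCNCCOc2c(OC)cccc2OC)cc1` gives 8.54. The moves between them are small: a number 0.23 log units lower from compound 1 to compound 2 (within the scatter), a number 0.01 log units higher from compound 1 to compound 3 (within the scatter) and a number 0.24 log units higher from compound 2 to compound 3 (within the scatter), so the three values sit within the scatter of one another and compound 3 is not separated from either neighbour. Compound 4 `COc1cccc(OC)c1OCCNCCOc1ccccc1OCc1ccc(OC(C)C)cc1` carries isopropyl in place of methyl on an oxygen on an aromatic ring. Among the measured compounds shown here, no measured step touches this oxygen; the three steps on the ring only show that changes there have so far left this assay unmoved. Compound 4 is therefore expected to show a number 0.04 log units lower from compound 3 to compound 4 (within the scatter), nothing beyond the scatter. The estimate for compound 4 is 8.5, within 7.9 to 9.1.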

Compound 4, negative logarithm of the antagonist equilibrium constant: 8.17
Estimate against measurement, compound 4: 0.33 log units above; the measured number falls inside the stated range.
By their numbers in this assay, from the lowest: compounds 4, 2, 1 and 3 (each within the scatter of the next, the first and the last beyond it).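

Isopropyl in place of methyl on an oxygen on an aromatic ring gives the first steps in the series beyond the scatter in this assay (a number 0.37 log units lower from compound 3 to compound 4 (beyond the scatter); a number 0.36 log units lower from compound 1 to compound 4 (beyond the scatter)), both modest. The 4-isopropoxyphenyl group is not separated from the 3-methoxyphenyl group (a number 0.13 log units lower from compound 2 to compound 4 (within the scatter)), so the change does not set compound 4 apart from the whole series. No evidence on the origin of these steps is at hand.

Open, going by these compounds, is whether ethyl or a longer chain on this oxygen would give a step of similar size. Also open, on these data alone, is whether 3-isopropoxyphenyl would read like 4-isopropoxyphenyl.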